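Butyl-to-hydrogen steps on two cores, growth inhibition

The compounds below may be only part of what the source reports. "The series", "measured", "known", "first", "only" and "open" are said of these compounds alone.

Measured in an ADME assay on 184B5 cells (Homo sapiens) for cytotoxicity, read by MTT assay, with a stated time of 72 h; a lower number here means a stronger inhibitor of growth, a higher number a weaker inhibitor of growth:
compound 1, `CCCCCSc1nc(NCc2ccc([Se]C)cc2)c2ccccc2n1`: 73000 nM
compound 2, `CSc1nc(NCc2ccc([Se]C)cc2)c2ccccc2n1`: 70300 nM
compound 3, `CCCCC[Se]c1nc(N)c2cccnc2n1`: 10300 nM

Compound 3 has the lowest number of the three. The difference between its core and the core of compound 1 is not broken down here.

Within the first core, hydrogen in place of butyl on a saturated chain carbon bound to a sulfur gave a 1.0-fold lower number from compound 1 to compound 2 (0.02 log units; within the scatter).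

Compound 4, `C[Se]c1nc(N)c2cccnc2n1`, is not yet measured. It follows from compound 3 by hydrogen in place of butyl on a saturated chain carbon bound to a selenium atom. The same kind of change, not the same, as that from compound 1 to compound 2: there the place is on a saturated chain carbon bound to a sulfur, here on a saturated chain carbon bound to a selenium atom.

Because a 1.0-fold lower number from compound 1 to compound 2 (0.02 log units; within the scatter) stayed within the scatter, a step of similar size is expected in this assay: a 1.1-fold higher number from compound 3 to compound 4 (0.03 log units; within the scatter). Compound 4 is accordingly estimated at 11000 nM, with a range from 4000 nM to 30000 nM.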

Compound 4, concentration for 50% growth inhibition: 45500 nM
Compound 4: the middle estimate sits 4.1-fold (0.62 log units) below what was measured, outside the stated range (above it).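

In this assay, hydrogen in place of butyl on a saturated chain carbon bound to a selenium atom gave a 4.4-fold higher number from compound 3 to compound 4 (0.65 log units; beyond the scatter). The change therefore does not carry over at a constant size from one core to the other: the same change on two cores in this assay, a 1.0-fold lower number (0.02 log units; within the scatter) from compound 1 to compound 2 and a 4.4-fold higher number (0.65 log units; beyond the scatter) from compound 3 to compound 4, 4.6-fold (0.66 log units) apart, beyond the scatter of two such steps

The two pairs differ both in the core and in the atom bearing the chain, a sulfur in one and a selenium atom in the other, and the gap cannot be assigned to either difference. Among the compounds shown here, each core also offers only one such pair, so no trend with chain length can be drawn.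

Still open, as far as these compounds go, is whether a propyl chain or a longer chain such as octyl on the selenium atom of the core of compound 3 would fall along the same step. Also open, from the compounds shown here alone, is how the same change behaves with sulfur on that core, or with a selenium atom in place of the sulfur on the core of compound 1.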